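A few compounds are considered here, and "the series" means these few. Any claim that something is new, unique, unknown or untested is made for them only; others in the source may bear on it.

- Compound 1 (`COC(=O)c1c(C)cc(OC(=O)c2c(C)cc(O)c(/C=N/NC(=O)Cc3ccccc3)c2O)c(C)c1O`) gives > 100000 nM in an ADME assay on HEK293 cells (Homo sapiens) for cytotoxicity (on this read-out higher numbers stand for weaker inhibition and lower numbers for stronger inhibition), as a limit of the assay.
- Compound 2 (`COC(=O)c1c(C)cc(OC(=O)c2c(C)cc(O)c(/C=N/NC(=O)CNc3ccc(C)cc3)c2O)c(C)c1O`) gives > 100000 nM in this assay as a limit of the assay.
- Compound 3 (`COC(=O)c1c(C)cc(OC(=O)c2c(C)cc(O)c(/C=N/NC(=O)COc3ccc(C)cc3)c2O)c(C)c1O`) gives > 100000 nM in this assay as a limit of the assay.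

Compound 3 stands at the limit of > 100000 nM in this assay, at which 3 of the 3 values shown sit, and so has no exact number. Compound 4 (`COC(=O)c1c(C)cc(OC(=O)c2c(C)cc(O)c(/C=N/NC(=O)COc3cc4ccccc4o3)c2O)c(C)c1O`) carries 1-benzofuran-2-yl in place of 4-methylphenyl on an oxygen on a saturated carbon. The measured changes closest to this one are a step that the two limits leave unreadable from compound 1 to compound 3 and a step that the two limits leave unreadable from compound 2 to compound 3 and neither has a size that can be read. No step beyond the usual scatter is therefore expected in this assay and no direction can be expected either. The expected outcome is a number no higher from compound 3 to compound 4 (the limit leaves the size open) in size. Compound 4 is estimated at 100000 nM (expected range 30000 nM to 200000 nM).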

Compound 4, half-maximal inhibitory concentration: 84400 nM
The estimate for compound 4 lay 1.2-fold (0.07 log units) above the measured number, within the range that was stated.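

Among these compounds, only compound 4, with 1-benzofuran-2-yl on the oxygen, gives an exact number in this assay, while the others sit at a limit of the assay: the limit of > 100000 nM in this assay, at which 3 of the 4 values shown sit.

Measured against those limits, the change reads as an at least 1.1-fold lower number from compound 3 to compound 4 (0.07 log units; that floor lies within the scatter), as an at least 1.1-fold lower number from compound 2 to compound 4 (0.07 log units; that floor lies within the scatter) and as an at least 1.1-fold lower number from compound 1 to compound 4 (0.07 log units; that floor lies within the scatter). Each of these is only a floor, and the steps among compound 1, compound 2 and compound 3 cannot be read.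

Going by these compounds, what an amine or a carboxylic acid in place of the 1-benzofuran-2-yl would do to this number stays open.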